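Amine replacement on the urea-bearing ring of the series

The source may hold more compounds than are shown below. What is called first, only, known or untested is meant among the compounds shown, and "the series" means these compounds.

Measured compounds:
- compound 1 `Cc1ccc(NC(=O)Nc2cc(-c3ccccc3C(=O)O)ccc2Oc2ccccc2C(C)(C)C)cc1`: 70 nM in an assay on HeLa cells for inhibition of Indoleamine 2,3-dioxygenase 1 (Homo sapiens), with stated times of 1 h and 18 h; on this read-out higher numbers stand for weaker inhibition and lower numbers for stronger inhibition
- compound 2 `Cc1ccc(NC(=O)Nc2cc(-c3ccccc3C(=O)O)ccc2N2CCC[C@@H]3CCCC[C@@H]32)cc1`: 159 nM in this assay

Among the measured compounds shown here, compound 2 stands at the higher of the two numbers in hand; the only measured step, a 2.3-fold higher number from compound 1 to compound 2 (0.36 log units; beyond the scatter), runs beyond the scatter but is modest in size.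

Compound 3 `Cc1ccc(NC(=O)Nc2cc(-c3ccccc3C(=O)O)ccc2N(CC2CC2)CC2CC2)cc1` is not yet measured. It differs from compound 2 in one place: a group of 9 heavy atoms (8 carbon, 1 nitrogen; 2 three-membered non-aromatic rings of carbon only) in place of a group of 10 heavy atoms (9 carbon, 1 nitrogen; one six-membered non-aromatic ring of carbon only, one six-membered non-aromatic ring with 1 hetero atom), on an aromatic carbon. The group sits on an aromatic carbon of a six-membered aromatic ring of carbon only, ortho to a ((4-methylphenyl)carbamoyl)amino group and para to a 2-carboxyphenyl group.

For the measured compounds named here, no measured step bears directly on this change. Going by the values given here, the one step known, from an aryl ether to the bicyclic amine, moved the number only modestly, and the present swap keeps an amine at the same position, trading two fused six-membered rings for two three-membered rings. The step of a 1.1-fold lower number from compound 2 to compound 3 (0.03 log units; within the scatter) is therefore expected to stay within or close to the scatter, in no firm direction. Compound 3 is estimated at 150 nM, with a range of 55 nM to 420 nM.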

Compound 3, half-maximal inhibitory concentration: 348 nM
Compound 3: middle estimate off by 2.3-fold (0.37 log units), on the low side; the range from low to high includes it.
By their numbers in this assay, from the lowest: compound 1; then compound 2; then compound 3.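

In this assay, keeping a nitrogen on this aromatic carbon does not hold the number steady: replacing the group with two six-membered non-aromatic rings by bis(cyclopropylmethyl)amino gives a 2.2-fold higher number from compound 2 to compound 3 (0.34 log units; beyond the scatter), so the position responds to what the amine carries as well as to the atom attached to the ring. Set against 2-(tert-butyl)phenoxy, the same amine gives a 5.0-fold higher number from compound 1 to compound 3 (0.70 log units; beyond the scatter), the widest gap among the three compounds, and both amines now lie on the higher-number side of the ether, with no compound shown going against that order. Nothing available on these compounds accounts for the differences among the three groups.

As far as these compounds go, it remains open whether a simpler amine at this position, such as dimethylamino or an unfused piperidine, would raise the number further or bring it back toward that of compound 1. Also open, from the compounds shown here alone, is whether the order of these three groups would hold with a tetrazole in place of the carboxylic acid on the 2-carboxyphenyl group.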